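A Swap of Aromatic Groups on a Shared Core

This account rests on a few compounds, and the source may have more. Where it says the series, first, only, none or still open, it means among the compounds named here.

Compound 1 `COc1cccc(CNc2ncnc3c2ncn3[C@@H]2O[C@H](CO)[C@@H](O)[C@H]2O)c1OC`: "not determined" (no result reported)
Compound 2 `OC[C@H]1O[C@@H](n2cnc3c(NCc4ccc(F)cc4F)ncnc32)[C@H](O)[C@@H]1O`: > 166000 nM

In a functional assay on B16 cells (Mus musculus) for antiproliferative activity, with a stated time of 72 h (a lower number here means a stronger inhibitor, a higher number a weaker inhibitor), compound 2 gives only a limit, > 166000 nM, not a number. This is the limit of > 166000 nM in this assay, at which 1 of the 2 values shown sits. For compound 1 no result was reported. Compound 3 `COc1cccc(CNc2ncnc3c2ncn3[C@@H]2O[C@H](CO)[C@@H](O)[C@H]2O)c1O` has not yet been measured. It differs from compound 2 in one place: 2-hydroxy-3-methoxyphenyl in place of 2,4-difluorophenyl on a saturated chain carbon bound to a nitrogen on an aromatic ring. No measured step joins any two of these compounds, so the size of this change cannot be read from the data; the step of an at least 1.1-fold lower number from compound 2 to compound 3 (0.04 log units; that floor lies within the scatter) is expected to be none beyond the usual scatter. Compound 3 is therefore estimated at 150000 nM, between 30000 nM and 600000 nM, with a fair chance of again only a limit.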

Compound 3, half-maximal inhibitory concentration: > 166000 nM
Compound 3 ended at the assay's limit; the forecaster's own chance of this, stated with the estimate: 60%; middle value at least 1.1-fold (0.04 log units) from the limit.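

Compound 2 and compound 3 both give only a limit in this assay, so no step between them can be read: the limit of > 166000 nM in this assay, at which 2 of the 3 values shown sit.

From the compounds shown here alone, whether 2-hydroxy-3-methoxyphenyl and 2,4-difluorophenyl differ at all in their effect on the shared core stays open.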